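Chain lengthening on two methoxyphenylbutyl amide cores

The source may hold more compounds than are shown below. What is called first, only, known or untested is meant among the compounds shown, and "the series" means these compounds.

Compound 1 `CCCC(=O)NCCCCc1cccc(OC)c1` is the reference point of this small set. In an assay for binding affinity to melatonin receptor (Gallus gallus) (on this read-out lower numbers stand for stronger inhibition and higher numbers for weaker inhibition), compound 1 gives 208 nM. Compound 2 `CCCCC(=O)NCCCCc1cccc(OC)c1` carries one change relative to compound 1, (methyl in place of hydrogen on a saturated chain carbon, three bonds along the chain from a carbonyl carbon), and in this assay compound 2 gives 9670 nM. The step of a 46-fold higher number from compound 1 to compound 2 (1.67 log units; beyond the scatter) is therefore a large loss of affinity on this core.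

Compound 3 `CCC(=O)NCCCCc1ccc(OC)cc1` belongs to a second core; how that core differs from the core of compound 1 is not broken down here. In this assay compound 3 gives 1400 nM, which places it between compound 1 and compound 2.

Compound 4 `CCCC(=O)NCCCCc1ccc(OC)cc1` is not yet measured. It differs from compound 3 by methyl in place of hydrogen on a saturated chain carbon, two bonds along the chain from a carbonyl carbon. Among the compounds with values here, this is the same kind of change as the one from compound 1 to compound 2, but not the same: in compound 2 the added methyl sits on a saturated chain carbon three bonds along the chain from a carbonyl carbon, whereas in compound 4 it sits two bonds along the chain from a carbonyl carbon, and the two cores are not identical. Within the data shown here, the only measured step of this kind, a 46-fold higher number from compound 1 to compound 2 (1.67 log units; beyond the scatter), was a large loss, so some caution is warranted, but it was taken on a different core and at a different place in the chain. He therefore expects a much smaller step for compound 4, roughly a 1.3-fold higher number from compound 3 to compound 4 (0.11 log units; within the scatter), with wide uncertainty. Compound 4 is estimated at 1800 nM in this assay, expected to lie between 350 nM and 9000 nM.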

Compound 4, inhibition constant: 822 nM
Compound 4: middle estimate off by 2.2-fold (0.34 log units), on the high side; the range from low to high includes it.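

In this assay, adding the methyl gives a 1.7-fold lower number from compound 3 to compound 4 (0.23 log units; within the scatter), so this step does not separate the two compounds, whereas the earlier step of this kind, a 46-fold higher number from compound 1 to compound 2 (1.67 log units; beyond the scatter), was a large loss of affinity. A large loss on the core of compound 1 therefore did not serve as a guide to the step on the core of compound 3, and the two steps clearly differ: the same change on two cores in this assay, a 46-fold higher number (1.67 log units; beyond the scatter) from compound 1 to compound 2 and a 1.7-fold lower number (0.23 log units; within the scatter) from compound 3 to compound 4, 79-fold (1.90 log units) apart, beyond the scatter of two such steps What this does not show is why they differ, since the core and the place of the methyl change together, three bonds along the chain from a carbonyl carbon in compound 2 and two bonds along the chain in compound 4, and each case rests on a single pair of compounds.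

The compounds shown leave open whether a methyl added to compound 4, three bonds along the chain from a carbonyl carbon, would bring the same large loss on that core, which would separate the effect of the core from that of the place. They also leave open how a branched chain, a cyclopropyl group or a hydroxyl on the chain would read in this assay on either core.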